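A few compounds are considered here, and "the series" means these few. Any claim that something is new, unique, unknown or untested is made for them only; others in the source may bear on it.

Measured so far:
compound 1, `Cc1ccc(NC(=O)N[C@@H](C)c2ccccc2)cc1` — 99%
compound 2, `CCCc1ccc(NC(=O)N[C@H](C)c2ccccc2)cc1` — 31%
compound 3, `CCCc1ccc(NC(=O)N[C@@H](C)c2ccccc2)cc1` — 76%

These three compounds share one core and were tested in an ADME assay on the whole organism with Oryza sativa as the target, tested at 1 uM; a higher number here means a weaker effect of the compound at the concentration tested, a lower number a stronger effect. Compound 2 has the lowest of the three numbers, giving 31%; the nearest to it is compound 3, and the furthest is compound 1. Two steps are known. From compound 1 to compound 3, ethyl in place of hydrogen on a saturated chain carbon bound to an aromatic carbon gave a number 23 percentage points lower from compound 1 to compound 3 (beyond the scatter). From compound 2 to compound 3, the change was a number 45 percentage points higher from compound 2 to compound 3 (beyond the scatter), and this rests on (the fact that compounds 2 and 3 differ only in the configuration as drawn).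

The next compound, compound 4, `CCOC(=O)c1ccc(NC(=O)N[C@H](C)c2ccccc2)cc1`, keeps the configuration of compound 2 and differs from it by ethoxycarbonyl in place of propyl on an aromatic carbon on an aromatic carbon of a six-membered aromatic ring of carbon only, para to a large group. Among the measured compounds shown here, neither measured step touches the group at that place, so no direct guide exists; the only change on that ring so far, from compound 1 to compound 3, was modest. A modest step, with the direction uncertain, is therefore expected, giving a number 19 percentage points higher from compound 2 to compound 4 (beyond the scatter). Compound 4 is estimated at 50%, within 20% to 85%.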

Compound 4, a percentage reported as activity, at one concentration (the size of the read-out at that concentration, not a potency): 100%
The estimate for compound 4 lay 50 percentage points below the measured number; measured number above the stated range.
By their numbers in this assay, from the lowest: compound 2; then compound 3; then compounds 1 and 4 (each within the scatter of the next).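

In this assay, ethoxycarbonyl in place of propyl on this aromatic carbon gave a number 69 percentage points higher from compound 2 to compound 4 (beyond the scatter) and so a much weaker effect at the concentration tested. The group on this carbon, para to a large group, can therefore decide the result, and the configuration shared by compound 2 and compound 4 does not keep the number low by itself. Nothing given here explains why this exchange acts so strongly.

The compounds shown leave open whether the opposite configuration would make any difference with ethoxycarbonyl in this place, as it does with propyl. They also leave open which groups here keep the effect of compound 2, for instance a butyl chain, a carboxylic acid or an amine.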